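This account rests on a few compounds, and the source may have more. Where it says the series, first, only, none or still open, it means among the compounds named here.

Compound 1 `CN(c1cccc2c1CN(c1nc(Nc3cc(C(F)(F)F)cc(C(F)(F)F)c3)ncc1C(F)(F)F)C2)S(C)(=O)=O` and compound 2 `Cc1cc(Cl)ccc1Nc1ncc(C(F)(F)F)c(N2Cc3cccc(N(C)S(C)(=O)=O)c3C2)n1` share the same core and differ only in the aryl group on the amine nitrogen. In an assay on Sf9 cells for inhibition of tyrosine-protein kinase receptor UFO (Homo sapiens), read by luminescence and ADP-Glo (on this read-out higher numbers stand for weaker inhibition and lower numbers for stronger inhibition), compound 1 gives > 20000 nM, which is a limit of the assay rather than a number. In this assay compound 2 gives > 20000 nM, again a limit and not a number. Going by the values given here, compound 2 therefore stands at the limit of > 20000 nM in this assay, at which 2 of the 2 values shown sit, and with both values being limits no step between compound 1 and compound 2 can be measured.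

Compound 3 `CN(c1cccc2c1CN(c1nc(Nc3ccc(Cl)c(C(F)(F)F)c3)ncc1C(F)(F)F)C2)S(C)(=O)=O` has not yet been measured. It differs from compound 2 in one place: 4-chloro-3-(trifluoromethyl)phenyl in place of 4-chloro-2-methylphenyl on a nitrogen on an aromatic ring. With compound 2 at the limit and compound 1 also sitting at the limit of > 20000 nM in this assay, at which 2 of the 2 values shown sit, no movement beyond the scatter is expected, and the expected step is a number no higher from compound 2 to compound 3 (the limit leaves the size open). Compound 3 is estimated at 20000 nM, within 5000 nM to 60000 nM, most likely reported once more as a limit only.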

Compound 3, half-maximal inhibitory concentration: > 20000 nM
Compound 3: no number, only a limit; the forecaster's own chance of this, stated with the estimate: 70%; the middle value sits exactly at the limit.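

In this assay compound 3 gives > 20000 nM, again a limit and not a number. Going by these compounds alone, compound 2 also sits at a limit, so no step between compound 2 and compound 3 can be read. The compounds shown leave open whether any aryl group on the shared core would give a number in this assay.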